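Swapping an Indole for a Bromophenyl on an Enone

This account rests on a few compounds, and the source may have more. Where it says the series, first, only, none or still open, it means among the compounds named here.

Measured so far:
compound 1 `CCOc1ccc(/C=C(/Sc2ccc(C)cc2)C(=O)c2ccc(Cl)cc2)cc1OC` — 25000 nM
compound 2 `Cc1ccc(CS(=O)(=O)/C(=C/c2c[nH]c3ccc(Br)cc23)C(=O)c2ccc(Cl)cc2)cc1` — 10000 nM
compound 3 `O=C(O)c1ccc(C(=O)/C(=C\c2ccc(F)c([N+](=O)[O-])c2)SCc2ccc(C(F)(F)F)cc2)cc1` — 1000 nM

All three values come from a functional assay on DU-145 cells (Homo sapiens) for inhibition, read by trypan blue exclusion, with a stated time of 96 h; on this read-out lower numbers stand for stronger inhibition of growth and higher numbers for weaker inhibition of growth. Compound 2 stands second highest of the three numbers. Its nearest neighbour is compound 1, which gives 25000 nM, a gap beyond the usual scatter; furthest away is compound 3, which gives 1000 nM, again beyond the scatter. These three compounds differ in several places at once, so no single change among them can be read off.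

Compound 4 `Cc1ccc(CS(=O)(=O)/C(=C/c2ccc(Br)cc2)C(=O)c2ccc(Cl)cc2)cc1` has not yet been measured. It differs from compound 2 in one place: 4-bromophenyl in place of 5-bromo-1H-indol-3-yl on a double-bonded chain carbon bound to a double-bonded chain carbon. The rest of the molecule is kept.

Among the measured compounds shown here, no measured pair shows this change on its own, so the expectation rests on the spread of the three numbers and on the change itself. The aryl groups in compound 1 and compound 3 are both six-membered carbon rings like the one entering here, and their values lie on either side of compound 2, giving no clear direction. The expected step from compound 2 to compound 4 in this assay is therefore a 1.5-fold higher number from compound 2 to compound 4 (0.18 log units; within the scatter), which is taken to be none beyond the scatter, with a modest lean towards weaker inhibition. Compound 4 is estimated to give 15000 nM, with a range from 5000 nM to 50000 nM.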

Compound 4, concentration for 50% growth inhibition: 25000 nM
The estimate for compound 4 lay 1.7-fold (0.22 log units) below the measured number; measured number inside the range.
By their numbers in this assay, from the lowest: compound 3; then compound 2; then compounds 1 and 4 (each within the scatter of the next).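

In this assay, among the compounds shown here, this is the first comparison in the set that changes only one place, and it shows that the group on this double-bonded chain carbon can shift the result: 4-bromophenyl in place of 5-bromo-1H-indol-3-yl gives a 2.5-fold higher number from compound 2 to compound 4 (0.40 log units; beyond the scatter). The change does several things at once, as the five-membered aromatic ring and the hydrogen-bond donor leave together and the entering group has fewer heavy atoms than the one it replaces, so this one step cannot show which of these differences matters. Nothing here explains why the number moves in this direction.

As far as these compounds go, it remains open whether a 5-bromo-1H-indol-3-yl group with a methyl in place of the hydrogen on its nitrogen would stay with compound 2 or move towards compound 4, which would separate the donor from the ring. From the compounds shown here alone, it is equally open how this position would respond to a phenyl ring carrying an amine in place of the bromine, or whether the same step would appear on a compound with a different sulfur-containing link.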